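This account rests on a few compounds, and the source may have more. Where it says the series, first, only, none or still open, it means among the compounds named here.

Measured in a functional assay on ID8 cells (Mus musculus) for antiproliferative activity; a lower number here means a stronger inhibitor, a higher number a weaker inhibitor:
- compound 1 `O=C(Nc1ccc(O)c2c(=O)cc(-c3ccccc3Cl)oc12)c1ccc(Cl)c(Cl)c1`: 13000 nM
- compound 2 `C[C@@H](NC(=O)OC(C)(C)C)C(=O)Nc1ccc(O)c2c(=O)cc(-c3ccccc3Cl)oc12`: 104000 nM
- compound 3 `C[C@H](NC(=O)OC(C)(C)C)C(=O)Nc1ccc(O)c2c(=O)cc(-c3ccccc3Cl)oc12`: 9800 nM

The low end of this small set is shared: a 1.3-fold lower number from compound 1 to compound 3 (0.12 log units; within the scatter). The other side of the set is compound 2, reached by an 8.0-fold higher number from compound 1 to compound 2 (0.90 log units; beyond the scatter). The largest gap is an 11-fold lower number from compound 2 to compound 3 (1.03 log units; beyond the scatter), because of the fact that compounds 2 and 3 differ only in the configuration as drawn.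

Compound 4 `CSCC[C@H](NC(=O)OC(C)(C)C)C(=O)Nc1ccc(O)c2c(=O)cc(-c3ccccc3Cl)oc12` carries (methylsulfanyl)methyl in place of hydrogen on a saturated chain carbon, two bonds along the chain from an amide-type nitrogen and a carbonyl carbon. Cut one bond further out, this reads methyl to 2-(methylsulfanyl)ethyl. Within the data shown here, no measured step changes this side chain, so the evidence is only indirect. The saturated chain carbon does matter in compound 3, as an 11-fold lower number from compound 2 to compound 3 (1.03 log units; beyond the scatter) shows, which argues for a wide range. Replacing the whole acyl group costs nothing clear in compound 3, as a 1.3-fold lower number from compound 1 to compound 3 (0.12 log units; within the scatter) shows, which argues against a large shift. In this assay, no step beyond the scatter is expected, and no direction can be called firmly. The estimated change is a 1.2-fold higher number from compound 3 to compound 4 (0.09 log units; within the scatter). The expected value for compound 4 is 12000 nM, with an estimated range of 4000 nM to 40000 nM.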

Compound 4, half-maximal inhibitory concentration: 6200 nM
The estimate for compound 4 lay 1.9-fold (0.29 log units) above the measured number; low and high end bracket the measured number.
By their numbers in this assay, from the lowest: compounds 4, 3 and 1 (each within the scatter of the next, the first and the last beyond it); then compound 2.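

In this assay, the side chain on this saturated chain carbon now has a direct reading (a 1.6-fold lower number from compound 3 to compound 4 (0.20 log units; within the scatter)). Going from methyl to 2-(methylsulfanyl)ethyl therefore brings no change beyond the scatter, so the position accepts a longer side chain containing sulfur without a clear shift in the number. The one large step at this carbon so far (an 11-fold lower number from compound 2 to compound 3 (1.03 log units; beyond the scatter)) concerns configuration and not side-chain size: the fact that compounds 2 and 3 differ only in the configuration as drawn

Still open, going by these compounds, is whether a configuration gap of that size also holds for the 2-(methylsulfanyl)ethyl side chain, as only the methyl pair shows it. Also open, on these data alone, is whether a carboxylic acid or a primary amine on this side chain would stay within the scatter of compound 3.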